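From 2-bromophenyl to furan-2-yl: compound 3 awaits measurement

The source may report more compounds than this note shows. Statements on the series, on what has been measured and on what is new or still open speak of the compounds shown alone.

In a functional assay on PC-3 cells (Homo sapiens) for inhibition, read by MTT assay, with a stated time of 48 h, tested at 10 uM (on this read-out higher numbers stand for more inhibition of growth at the one concentration tested and lower numbers for less inhibition of growth), compound 1 `Cc1cc(=O)c2c(O)cc(OCc3ccc([N+](=O)[O-])cc3)c([C@H]3CCN(C)C[C@H]3O)c2o1` gives 23% and compound 2 `Cc1cc(=O)c2c(O)cc(OCc3ccccc3Br)c([C@H]3CCN(C)C[C@H]3O)c2o1` gives 32%, so compound 2 stands level with compound 1 within the scatter. Compound 3 `Cc1cc(=O)c2c(O)cc(OCc3ccco3)c([C@H]3CCN(C)C[C@H]3O)c2o1` carries furan-2-yl in place of 2-bromophenyl on a saturated chain carbon bound to an oxygen on an aromatic ring. Within the data shown here, the one measured step at this place, a number 9 percentage points higher from compound 1 to compound 2 (within the scatter), is the only guide, so no step beyond the scatter is expected. The estimated step is a number 5 percentage points lower from compound 2 to compound 3 (within the scatter). For compound 3 the expected value in this assay is 27%, with an estimated range of 12% to 42%.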

Compound 3, percent growth inhibition at one concentration: 14%
Beside the measured number, compound 3's estimate is 13 percentage points above it, within the range that was stated.
By their numbers in this assay, from the lowest: compounds 3, 1 and 2 (each within the scatter of the next, the first and the last beyond it).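

In this assay, the place on a saturated chain carbon bound to an oxygen on an aromatic ring now shows a step beyond the scatter: furan-2-yl in place of 2-bromophenyl gives a number 18 percentage points lower from compound 2 to compound 3 (beyond the scatter) and so shows that this place can respond to the group it carries. Furan-2-yl in place of 4-nitrophenyl gives a number 9 percentage points lower from compound 1 to compound 3 (within the scatter) and stays within the scatter, so only the pair with 2-bromophenyl separates. No measurement at hand offers an explanation for this step.

Open remains how a plain phenyl, a thiophen-2-yl or a cyclohexyl group would read at this place, and so whether the bromine or the change of ring goes with the step.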